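A Butyl Amide Variant of a Weak Kinase Inhibitor

This account rests on a few compounds, and the source may have more. Where it says the series, first, only, none or still open, it means among the compounds named here.

Compound 1, `COC(=O)c1cc2c(Nc3ccccc3)[nH]nc2s1`: 21000 nM
Compound 2, `Cc1n[nH]c2sc(C(N)=O)cc12`: > 20000 nM

In an assay on isolated protein for inhibition of serine/threonine-protein kinase PLK1 (Homo sapiens) (on this read-out higher numbers stand for weaker inhibition and lower numbers for stronger inhibition), compound 1 gives 21000 nM. Compound 2 gives only a limit of the assay, > 20000 nM, so where it stands is known only as the limit of > 20000 nM in this assay, at which 1 of the 2 values shown sits. Compound 3, `CCCCNC(=O)c1cc2c(C)n[nH]c2s1`, differs from compound 2 by butyl in place of hydrogen on an amide-type nitrogen. Among the compounds with values here, no measured pair shows this change, so its size is unknown; the expectation is a shift no larger than the usual scatter, in no particular direction. Compound 3 is therefore expected to give about 20000 nM, between 5000 nM and 60000 nM, an estimated step of a number no higher from compound 2 to compound 3 (the limit leaves the size open).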

Compound 3, half-maximal inhibitory concentration: > 20000 nM
Compound 3: no number, only a limit; the forecaster's own chance of this, stated with the estimate: 55%; the middle value sits exactly at the limit.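

No step can be read from compound 2 to compound 3, because each gives only a limit and no number: the limit of > 20000 nM in this assay, at which 2 of the 3 values shown sit. As far as these compounds go, whether butyl in place of hydrogen on an amide-type nitrogen changes inhibition at all stays open.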